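The source may report more compounds than this note shows. Statements on the series, on what has been measured and on what is new or still open speak of the compounds shown alone.

Measured so far: compound 1 `COC(=O)C1=CN(C(C)C)C(=O)[C@@H]2C(CN3CCN(Cc4ccc([N+](=O)[O-])cc4)CC3)=CC[C@H]12`, 67.1%; compound 2 `COC(=O)C1=CNC(=O)[C@@H]2C(CO)=CC[C@H]12`, 59%.

In a functional assay on Cortical neurone cells (Rattus norvegicus, strain Sprague-Dawley), read by MTT assay, with stated times of 24 h and 2 h, tested at 0.1 uM (on this read-out lower numbers stand for a weaker effect and higher numbers for a stronger effect at the one concentration tested), compound 1 gives 67.1%, and compound 2 gives 59%. Among the compounds with values here, the two numbers lie within the usual scatter of each other, so compound 1 stands level with the only other measured compound rather than apart from it. Compound 3 `COC(=O)C1=CN(C(C)C)C(=O)[C@@H]2C(CN3CCN(Cc4cccc(OC)c4)CC3)=CC[C@H]12` differs from compound 1 in one place: 3-methoxyphenyl in place of 4-nitrophenyl on a saturated chain carbon bound to an amine nitrogen in a ring. Within the data shown here, no measured pair shows this change, so nothing here tells how large its step should be. The step of a number 2.1 percentage points lower from compound 1 to compound 3 (within the scatter) is expected to be none beyond the scatter. Compound 3 is accordingly estimated at 65%, in a range from 45% to 85%.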

Compound 3, a percentage reported as activity, at one concentration (the size of the read-out at that concentration, not a potency): 60.6%
The estimate for compound 3 lay 4.4 percentage points above the measured number, and the stated range covers the measured number.
By their numbers in this assay, from the lowest: compounds 2, 3 and 1 (each within the scatter of the next).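

In this assay the exchange of 4-nitrophenyl for 3-methoxyphenyl gives a number 6.5 percentage points lower from compound 1 to compound 3 (within the scatter) and so shows that this place on the saturated chain carbon tolerates a second substituted phenyl without a step beyond the scatter. Because the group and its substitution site change together, this single step cannot separate the two. No measurement on hand accounts for the size of the step. Going by these compounds, whether an unsubstituted phenyl, a pyridine or a carboxylic acid on the ring would also stay level with compound 1 remains open.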